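Pyrrolidin-1-yl for diethylamino in compound 3

The source may report more compounds than this note shows. Statements on the series, on what has been measured and on what is new or still open speak of the compounds shown alone.

In an ADME assay on L6 cells (Rattus norvegicus) for cytotoxicity (on this read-out higher numbers stand for weaker inhibition and lower numbers for stronger inhibition), compound 1 `CCN(CC)CC(=O)OC1CC2(N(C)C)CC(c3ccccc3)C1C(c1ccccc1)C2` gives 30100 nM, compound 2 `CN(C)C12CC(OC(=O)CN3CCCC3)C(C(c3ccccc3)C1)C(c1ccccc1)C2` gives 32700 nM and compound 3 `CCN(CC)CCC(=O)OC1CC2(N(C)C)CC(c3ccccc3)C1C(c1ccccc1)C2` gives 23600 nM. All three numbers lie within the scatter of one another, so compound 3 stands level with the other two. Compound 4 `CN(C)C12CC(OC(=O)CCN3CCCC3)C(C(c3ccccc3)C1)C(c1ccccc1)C2` has not yet been measured in this assay. Its difference from compound 3 is pyrrolidin-1-yl in place of diethylamino on a saturated chain carbon, two bonds along the chain from a carbonyl carbon, with pyrrolidin-1-yl in place of diethylamino on a saturated chain carbon, two bonds along the chain from a carbonyl carbon. The closest measured precedent is the same exchange on a saturated chain carbon bound to a carbonyl carbon, which gave a 1.1-fold higher number from compound 1 to compound 2 (0.04 log units; within the scatter). The other two measured steps also stayed small, at a 1.3-fold lower number from compound 1 to compound 3 (0.11 log units; within the scatter) and a 1.4-fold lower number from compound 2 to compound 3 (0.14 log units; within the scatter). No step beyond the scatter is therefore expected, and the estimate amounts to a 1.1-fold higher number from compound 3 to compound 4 (0.03 log units; within the scatter). Compound 4 is expected at 25000 nM, within an estimated range of 13000 nM to 48000 nM.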

Compound 4, half-maximal inhibitory concentration: 26000 nM
Beside the measured number, compound 4's estimate is 1.0-fold (0.02 log units) below it; measured number inside the range.
By their numbers in this assay, from the lowest: compounds 3, 4, 1 and 2 (each within the scatter of the next).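

In this assay, the exchange of diethylamino for pyrrolidin-1-yl can now be read on a second chain, on a saturated chain carbon, two bonds along the chain from a carbonyl carbon, where it gives a 1.1-fold higher number from compound 3 to compound 4 (0.04 log units; within the scatter). The pyrrolidine series can also now be read across the two chain forms, with (pyrrolidin-1-yl)methyl in place of pyrrolidin-1-yl giving a 1.3-fold lower number from compound 2 to compound 4 (0.10 log units; within the scatter), while (pyrrolidin-1-yl)methyl in place of diethylamino gives a 1.2-fold lower number from compound 1 to compound 4 (0.06 log units; within the scatter). The exchange thus reads alike at both places: the same change on two cores in this assay, a 1.1-fold higher number (0.04 log units; within the scatter) from compound 1 to compound 2 and a 1.1-fold higher number (0.04 log units; within the scatter) from compound 3 to compound 4, 1.0-fold (0.01 log units) apart, within the scatter of two such steps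

As far as these compounds go, whether a morpholin-4-yl group, a primary amine or a longer chain such as 3-(diethylamino)propyl would also stay within the scatter remains open. From the compounds shown here alone, all four numbers come from this assay, so the exchange in any other read-out remains open too.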